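Pyrrolyl analogue of the thiourea series: cytotoxicity outlook

A few compounds are considered here, and "the series" means these few. Any claim that something is new, unique, unknown or untested is made for them only; others in the source may bear on it.

Measured so far:
compound 1 `NC(=S)Nc1cccc(OCCCCCOc2ccccc2)c1`: > 50000 nM
compound 2 `CC(CCOc1ccccc1)CCOc1cccc(NC(N)=S)c1`: > 50000 nM
compound 3 `NC(=S)Nc1cccc(OCCCCCOc2cccc(C(=O)c3ccccc3)c2)c1`: 13000 nM

In an ADME assay on Ava5 cells (Homo sapiens) for cytotoxicity (on this read-out higher numbers stand for lower toxicity in this test and lower numbers for higher toxicity in this test), compound 1 gives > 50000 nM, which is a limit of the assay and not a number. Compound 2 also sits at a limit, > 50000 nM. Compound 3, which carries a benzoyl, gives 13000 nM. Compound 1 therefore stands at the ceiling of the series, the point where two of the three values rest (the limit of > 50000 nM in this assay, at which 2 of the 3 values shown sit). The step that the two limits leave unreadable from compound 1 to compound 2 tells nothing about the size of that change, as both ends are limits. The step of an at least 3.8-fold lower number from compound 1 to compound 3 (0.58 log units; beyond the scatter) is the one that bears on the new compound, since it is the only measured addition of a group to the ring that also receives the new substituent.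

Compound 4 `NC(=S)Nc1cccc(OCCCCCOc2ccc(-n3cccc3)cc2)c1` differs from compound 1 as follows: 1H-pyrrol-1-yl in place of hydrogen on an aromatic carbon. By analogy with compound 3 a move toward a lower number is expected, of a size that reaches beyond the scatter, though the smaller ring entering may mean a lesser step than the benzoyl gave. The estimate for compound 4 is 30000 nM, within 10000 nM to 80000 nM, which corresponds to an expected step of an at least 1.6-fold lower number from compound 1 to compound 4 (0.22 log units; that floor lies within the scatter); a result that again reports only a limit remains quite possible.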

Compound 4, half-maximal cytotoxic concentration: > 50000 nM
Compound 4 was reported as a limit; the forecaster's own chance of this, stated with the estimate: 40%; at least 1.6-fold (0.22 log units) between middle value and limit.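

Compound 4 gives > 50000 nM, a limit and not a number. Within the data shown here, compound 1 also rests at a limit, so no step between compound 1 and compound 4 can be read. The compounds shown leave open whether 1H-pyrrol-1-yl in place of hydrogen changes the read-out at all.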